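The source may report more compounds than this note shows. Statements on the series, on what has been measured and on what is new or still open speak of the compounds shown alone.

Three thiosemicarbazones were tested in an ADME assay on Vero cells (Chlorocebus sabaeus) for cytotoxicity, read by MTT assay, with a stated time of 72 h; on this read-out lower numbers stand for higher toxicity in this test and higher numbers for lower toxicity in this test. Compound 1, `Cc1ccccc1/C=N\NC(=S)N(Cc1ccccc1)Cc1ccccc1`, gives 167000 nM in this assay. Compound 2, `C=CCN(CC=C)C(=S)N/N=C\c1ccc(Cl)cc1`, gives 213000 nM, and compound 3, `C/C(=N/NC(=S)N(Cc1ccccc1)Cc1ccccc1)c1ccccc1O`, gives 160000 nM. On these numbers compound 1 sits amid the other two: its value lies close to that of compound 3 and somewhat further from that of compound 2, yet all three numbers fall within the usual scatter of one another, so no ordering among them can be read from this assay. Compound 4, `O=[N+]([O-])c1ccc(/C=N\NC(=S)N(Cc2ccccc2)Cc2ccccc2)cc1`, has not yet been measured there. It differs from compound 1 in one place: 4-nitrophenyl in place of 2-methylphenyl on a carbon with a double bond to nitrogen. Since the three measured compounds carry quite different aryl groups and still return indistinguishable numbers, the exchange of 2-methylphenyl for 4-nitrophenyl is expected to shift the read-out by a 1.0-fold higher number from compound 1 to compound 4 (0.01 log units; within the scatter), that is, by nothing beyond the scatter. Compound 4 is therefore estimated at 170000 nM, within a range from 90000 nM to 320000 nM.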

Compound 4, half-maximal cytotoxic concentration: < 155000 nM
Compound 4: no number, only a limit; the forecaster's own chance of this, stated with the estimate: 20%; middle value at least 1.0-fold (0.04 log units) from the limit.
By their numbers in this assay, from the lowest: compounds 3, 1 and 2 (each within the scatter of the next). At a limit, below all of these: compound 4.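

In this assay compound 4 returns a limit and not a number: the limit of < 155000 nM in this assay, at which 1 of the 4 values shown sits. Read against compound 1, 4-nitrophenyl in place of 2-methylphenyl on a carbon with a double bond to nitrogen gives an at least 1.0-fold lower number from compound 1 to compound 4 (0.03 log units; that floor lies within the scatter), so only a floor for the step is known, and how far the true value lies past the limit is not fixed. For the compounds shown here, the earlier compounds included no pair differing in one place, so this is the first step at this position, and it allows either a difference within the scatter or a larger one towards higher toxicity in this test.

The compounds shown leave open what a number for compound 4 would be. They also leave open how the read-out would respond to an amine or a carboxylic acid on the aromatic ring at this place.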